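A few compounds are considered here, and "the series" means these few. Any claim that something is new, unique, unknown or untested is made for them only; others in the source may bear on it.

Compound 1 `O=c1[nH]cc(S(=O)(=O)Nc2ccccc2-c2cn(-c3ccccc3F)nn2)c(=O)[nH]1` gives 7370 nM in a functional assay on A549 cells (Homo sapiens) for antiproliferative activity, read by MTT assay, with a stated time of 24 h; a lower number here means a stronger inhibitor, a higher number a weaker inhibitor. Compound 2 `O=c1[nH]cc(S(=O)(=O)Nc2ccccc2-c2cn(-c3cccc(F)c3)nn2)c(=O)[nH]1` gives 8130 nM. Compound 3 `O=c1[nH]cc(S(=O)(=O)Nc2cccc(-c3cn(-c4ccccc4)nn3)c2)c(=O)[nH]1` gives 12700 nM.

Compound 3 carries the highest of the three numbers, yet its gaps to compound 2 and compound 1 both lie within the scatter, so no order among the three can be drawn. Compound 4 `O=c1[nH]cc(S(=O)(=O)Nc2cccc(-c3cn(-c4ccccc4Cl)nn3)c2)c(=O)[nH]1` differs from compound 3 by chloro in place of hydrogen on an aromatic carbon. Within the data shown here, no measured pair isolates this change. Among the measured compounds shown here, the only measured step, a 1.1-fold higher number from compound 1 to compound 2 (0.04 log units; within the scatter), involves a halogen on the same aromatic ring and is within the scatter, so it bears on compound 4 only loosely. A step no larger than the scatter is therefore expected, estimated as a 1.3-fold lower number from compound 3 to compound 4 (0.10 log units; within the scatter). Compound 4 is expected to give 10000 nM, with a range from 4000 nM to 25000 nM.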

Compound 4, half-maximal inhibitory concentration: 2730 nM
For compound 4 the middle estimate is 3.7-fold (0.56 log units) above the measured one; the whole stated range lies above it.
By their numbers in this assay, from the lowest: compound 4; then compounds 1, 2 and 3 (each within the scatter of the next).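

In this assay, chloro in place of hydrogen on an aromatic carbon, ortho to a large group, gives a 4.7-fold lower number from compound 3 to compound 4 (0.67 log units; beyond the scatter). This is the only step shown that lies beyond the scatter, so this position on the phenyl ring responds to a substituent, which the move of fluoro between compound 1 and compound 2 did not show. Nothing available explains why this step occurs. From the compounds shown here alone, whether a methoxy group or an amine at this position would give a similar step remains open. Going by these compounds, it is also open whether the same change would carry over to the core of compound 1.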